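Extending the saturated chain from compound 3 to compound 4

A few compounds are considered here, and "the series" means these few. Any claim that something is new, unique, unknown or untested is made for them only; others in the source may bear on it.

Compound 1 `Cc1cc(-c2ccc(F)cc2)n(Cc2ccc(C(=O)NO)cc2)n1` and compound 2 `Cc1ccc(-c2cc(C)nn2Cc2ccc(C(=O)NO)cc2)cc1` carry the hydroxamic acid on an arm of the shared core, while compound 3 `O=C(CCCNC(=O)c1cc(-c2ccc(F)cc2)[nH]n1)NO` carries it on a saturated chain linked through an amide. In an assay on cells for inhibition of protein deacetylase HDAC6 (Homo sapiens), read by fluorescence, with stated times of 15 min and 60 min (a higher number here means a weaker inhibitor, a lower number a stronger inhibitor), compound 1 gives 20 nM, compound 2 gives 29 nM and compound 3 gives 1060 nM. For the measured compounds named here, the only one-place step among the measured compounds, a 1.5-fold higher number from compound 1 to compound 2 (0.16 log units; within the scatter), lies within the scatter. Compound 3 gives the highest of the three numbers, and its gap to each of compound 1 and compound 2 is beyond the scatter. Compound 4 `O=C(CCCCNC(=O)c1cc(-c2ccc(F)cc2)[nH]n1)NO` differs from compound 3 by (hydroxycarbamoyl)methyl in place of hydroxycarbamoyl on a saturated chain carbon, three bonds along the chain from an amide-type nitrogen. Going by the values given here, no measured step touches the length of this chain; the single measured step concerns the aromatic substituent and does not bear on the change. The expectation for compound 4 therefore rests on compound 3 alone. The expected step, a 1.3-fold lower number from compound 3 to compound 4 (0.12 log units; within the scatter), stays within the scatter. For compound 4 in this assay the estimate is 800 nM, with a range from 250 nM to 2500 nM.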

Compound 4, half-maximal inhibitory concentration: 275 nM
Compound 4: the middle estimate sits 2.9-fold (0.46 log units) above what was measured; low and high end bracket the measured number.
By their numbers in this assay, from the lowest: compounds 1 and 2 (each within the scatter of the next); then compound 4; then compound 3.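

Lengthening the saturated chain is the first measured change at this position, on a saturated chain carbon, three bonds along the chain from an amide-type nitrogen. In this assay, for the compounds shown here, (hydroxycarbamoyl)methyl in place of hydroxycarbamoyl gives a step beyond the scatter (a 3.9-fold lower number from compound 3 to compound 4 (0.59 log units; beyond the scatter)), so the number responds to this change, whereas the only earlier step (a 1.5-fold higher number from compound 1 to compound 2 (0.16 log units; within the scatter)) concerned an aromatic substituent and stayed within the scatter. This is a single step between two chain lengths and not yet a trend, and nothing measured here explains it.

From the compounds shown here alone, whether a longer chain than that of compound 4 lowers the number further remains open. Also open, going by these compounds, is whether the same lengthening has a similar effect with methyl in place of fluoro on the aromatic carbon.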